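The source may hold more compounds than are shown below. What is called first, only, known or untested is meant among the compounds shown, and "the series" means these compounds.

The two compounds measured so far in an ADME assay (liver) for metabolic stability, with Liver microsome (Homo sapiens) as the target, read by LC-MS, using microsomes and NADPH, with a stated time of 5 min, at 37 degrees C (a higher number here means faster removal of the compound, a lower number slower removal), are:

Compound 1 `CCn1c(C(C)NS(=O)(=O)c2ccc(Cl)cc2)nc2ncccc21` gives 15 mL.min-1.g-1 in this assay.
Compound 2 `CCn1c([C@@H](C)NS(=O)(=O)c2ccc(C)cc2)nc2ccc(C(F)(F)F)cc21` gives only a limit in this assay, > 100 mL.min-1.g-1.

Compound 2 therefore does not stand at a number but at a limit, (the limit of > 100 mL.min-1.g-1 in this assay, at which 1 of the 2 values shown sits), and the gap to compound 1 can only be read as being at least as large as the difference between that limit and the value of compound 1. Within the data shown here, no pair of measured compounds differing in a single place is available, so the size of any one structural step in this assay is not yet known.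

Compound 3 `CCn1c([C@@H](C)NS(=O)(=O)c2cn(C)c(C)n2)nc2ccc(C(F)(F)F)cc21` is the next compound to be measured. It differs from compound 2 in one place: 1,2-dimethyl-1H-imidazol-4-yl in place of 4-methylphenyl on a sulfonyl sulfur.

Since compound 2 sits at the limit, any step from it can only be read in the downward direction or not at all. The expectation is a downward step of an at least 2.2-fold lower number from compound 2 to compound 3 (0.34 log units; beyond the scatter), beyond the usual scatter, with a real chance that compound 3 again returns only the limit. Compound 3 is estimated at 45 mL.min-1.g-1 in this assay, within a range of 15 mL.min-1.g-1 to 100 mL.min-1.g-1.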

Compound 3, intrinsic clearance in microsomes: 43 mL.min-1.g-1
Beside the measured number, compound 3's estimate is 1.0-fold (0.02 log units) above it; the measured number falls inside the stated range.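

In this assay, among these compounds, the sulfonyl sulfur proves to be a place where the choice of group can move the number: 1,2-dimethyl-1H-imidazol-4-yl in place of 4-methylphenyl gives an at least 2.3-fold lower number from compound 2 to compound 3 (0.36 log units; beyond the scatter), the first step between measured compounds that differ in one place. The two groups carry the same count of heavy atoms, 7, and neither has a hydrogen-bond donor, while the entering ring holds 2 hydrogen-bond acceptors and the leaving ring none, so the step comes with a change of ring and of acceptor count rather than of heavy-atom count. The full size of the step cannot be read, because compound 2 stands at a limit rather than at a number: the limit of > 100 mL.min-1.g-1 in this assay, at which 1 of the 3 values shown sits.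

The compounds shown do not tell whether the step follows the ring nitrogens or the two methyl groups, and they do not show how a pyridine ring or a cyclopropyl group on the sulfonyl sulfur would read in this assay. Going by these compounds, it also remains open whether the same exchange would give a step of similar size on the core of compound 1.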